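A few compounds are considered here, and "the series" means these few. Any claim that something is new, unique, unknown or untested is made for them only; others in the source may bear on it.

Of the compounds shown here, three share one core and have already been tested. Compound 1 `CCN1CCN(c2ccc(Nc3ncc(Cl)c(Nc4ccccc4C)n3)nc2)CC1` carries an ethylpiperazine on a pyridine and a methyl on the anilino ring. In a functional assay on MDA-MB-231 cells (Homo sapiens) for inhibition, read by CCK-8 assay, with a stated time of 48 h (a lower number here means a stronger inhibitor of growth, a higher number a weaker inhibitor of growth), compound 1 reaches only the assay limit of > 100000 nM, a boundary rather than a number, and the limit of > 100000 nM in this assay, at which 1 of the 3 values shown sits, marks that ceiling. Compound 2 `CCN1CCN(c2ccc(Nc3ncc(Cl)c(Nc4ccccc4C)n3)cc2)CC1` keeps the same groups but replaces the pyridine with a benzene ring, and in this assay compound 2 gives 3040 nM. Compound 3 `CN1CCN(c2ccc(Nc3ncc(Cl)c(Nc4ccccc4)n3)nc2)CC1` returns to the pyridine, now bearing a methylpiperazine, and carries a plain anilino group; in this assay compound 3 gives 37400 nM. Of the two numbers actually measured, compound 3 holds the higher one and compound 2 the lower, and that gap is beyond the usual scatter of repeated runs.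

Compound 4 `Cc1ccc(Nc2nc(Nc3ccc(N4CCN(C)CC4)cn3)ncc2Cl)cc1` is the untested neighbour of compound 3. The change is methyl in place of hydrogen on an aromatic carbon, para to a large group. Going by the values given here, no pair already measured differs by this change alone, so no measured step guides the direction. The step from compound 3 to compound 4 is expected to be modest, a 1.5-fold lower number from compound 3 to compound 4 (0.17 log units; within the scatter), without a clear direction beyond the scatter. Compound 4 is therefore estimated at 25000 nM, most likely between 6000 nM and 100000 nM.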

Compound 4, concentration for 50% growth inhibition: 4030 nM
The estimate for compound 4 lay 6.2-fold (0.79 log units) above the measured number; measured number outside the range, below it.
By their numbers in this assay, from the lowest: compounds 2 and 4 (each within the scatter of the next); then compound 3. At a limit, above all of these: compound 1.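

In this assay, the change from phenyl to 4-methylphenyl, with the methyl para to a large group, gives a 9.3-fold lower number from compound 3 to compound 4 (0.97 log units; beyond the scatter) and provides the only direct reading of this position among the compounds shown. The earlier compounds shown here formed no measured step, so they could not show that one added methyl, a single carbon with no ring and no hydrogen-bond donor or acceptor, can by itself shift growth inhibition beyond the usual scatter. Nothing measured here accounts for the size of this shift, so the data record that it occurs without explaining it.

The compounds shown leave open whether the shift is particular to methyl or would also appear with another group at this place, such as methoxy, an amine or a carboxylic acid. They also leave open whether moving the methyl elsewhere on the ring, or adding it to a compound with a different piperazine or a benzene in place of the pyridine, would produce a step of similar size.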